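Chloro Substitution and Cytotoxicity in Liver-Derived Cells

This account rests on a few compounds, and the source may have more. Where it says the series, first, only, none or still open, it means among the compounds named here.

Of the compounds shown here, two sharing one core have been tested for how strongly they harm cultured liver cells. Compound 1 `O=C(O)/C(O)=C/C(=O)c1ccccc1OCc1ccc(Cl)cc1` already carries a chloro group on its outer ring. In an ADME assay on Huh-7 cells (Homo sapiens) for cytotoxicity (on this read-out lower numbers stand for higher toxicity in this test and higher numbers for lower toxicity in this test), compound 1 reaches only the limit of the test, giving > 100000 nM. Compound 2 `O=C(O)/C(O)=C/C(=O)c1cccc(NCc2ccccc2)c1` attaches its outer ring to the core differently. In this assay compound 2 also gives only the limit, > 100000 nM. Both results therefore sit at the limit of > 100000 nM in this assay, at which 2 of the 2 values shown sit, meaning no measurable toxicity in this test for either. Compound 3 `O=C(O)/C(O)=C/C(=O)c1cccc(NCc2ccc(Cl)cc2)c1` is compound 2 with one small change: chloro in place of hydrogen on an aromatic carbon. Within the data shown here, no measured pair differing in a single place is available, so the size of this step has not been observed directly. Because compound 1 carries the same chloro group and still gives > 100000 nM, little movement is expected. The step from compound 2 to compound 3 is expected to be a step that the limit leaves unreadable from compound 2 to compound 3, nothing beyond the scatter. Compound 3 is estimated at 150000 nM, within 70000 nM to 400000 nM, most likely reported again only as a limit.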

Compound 3, half-maximal cytotoxic concentration: > 100000 nM
Compound 3 ended at the assay's limit; the forecaster's own chance of this, stated with the estimate: 85%; the middle value lies beyond the limit too.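

Compound 2 and compound 3 both stop at the limit of this assay, so the step from hydrogen to chloro cannot be read. The compounds shown leave open whether any change to the shared core would give a measurable number in this assay: the limit of > 100000 nM in this assay, at which 3 of the 3 values shown sit.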